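Replacing the anilino end of compound 1 with a hydroxyethoxy tail

A few compounds are considered here, and "the series" means these few. Any claim that something is new, unique, unknown or untested is made for them only; others in the source may bear on it.

Measured compounds:
Compound 1, `c1ccc(COc2ccc(OCCOCCNc3ccccc3)cc2)cc1`, in a functional assay on SK-OV-3 cells (Homo sapiens) for inhibition, read by CCK-8 assay, with a stated time of 70 h (on this read-out lower numbers stand for stronger inhibition and higher numbers for weaker inhibition), gives > 100000 nM, which is a limit of the assay and not a number.
Compound 2, `O=[N+]([O-])c1ccc(COc2ccc(OCCOCCNC3CCCC3)cc2)cc1`, gives 20300 nM.
Compound 3, `Nc1ccc(COc2ccc(OCCOCCNC3CCCC3)cc2)cc1`, gives 31700 nM.

Among the compounds with values here, compound 1 stands at the limit of > 100000 nM in this assay, at which 1 of the 3 values shown sits; of the three compounds, it is the only one for which no number is known. Compound 4, `OCCOCCOCCOc1ccc(OCc2ccccc2)cc1`, differs from compound 1 by 2-hydroxyethoxy in place of anilino on a saturated chain carbon, two bonds along the chain from an oxygen on a saturated carbon.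

Within the data shown here, the only measured step, a 1.6-fold higher number from compound 2 to compound 3 (0.19 log units; within the scatter), concerns a change on the aromatic ring of a different pair, with the pentyl-type amine end kept; it does not touch the anilino part and so gives no direct guide to the step from compound 1 to compound 4. Compound 2 and compound 3 lie within the scatter of each other.

Among the measured compounds shown here, with compound 1 sitting at the limit and no step that bears on the exchange of the anilino group, the number for compound 4 is expected to remain near that limit, so that a step that the limit leaves unreadable from compound 1 to compound 4 is expected to be no more than the scatter. Compound 4 is therefore estimated at 150000 nM, with a range from 50000 nM to 500000 nM.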

Compound 4, half-maximal inhibitory concentration: 59400 nM
Estimate against measurement, compound 4: 2.5-fold (0.40 log units) above; low and high end bracket the measured number.
By their numbers in this assay, from the lowest: compounds 2, 3 and 4 (each within the scatter of the next, the first and the last beyond it). At a limit, above all of these: compound 1.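

In this assay compound 4 gives 59400 nM, so with 2-hydroxyethoxy in place of anilino on a saturated chain carbon, the core of compound 1 now has a readable number. Compound 1 gives > 100000 nM, which is a limit of the assay and not a number. The exchange therefore reads as an at least 1.6-fold lower number from compound 1 to compound 4 (0.22 log units; that floor lies within the scatter), and this step can only be given as a floor because one end of it is a limit: the limit of > 100000 nM in this assay, at which 1 of the 4 values shown sits.

Going by these compounds, the true size of the step remains open, and so does whether it goes beyond the scatter. On these data alone, it is also open how this assay would respond to a carboxylic acid, a primary amine or a longer chain at this same place on the core.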